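This account rests on a few compounds, and the source may have more. Where it says the series, first, only, none or still open, it means among the compounds named here.

Measured so far: compound 1 `NS(=O)(=O)c1ccc(CNc2ccnc(Nc3cccc(NC(=O)N4CCCC4)c3)n2)cc1` and compound 2 `O=C(NCCCNc1ccnc(Nc2cccc(NC(=O)N3CCCC3)c2)n1)C1CCC1`.

In an assay on HEK293 cells for displacement of a labelled ligand from serine/threonine-protein kinase 17A (Homo sapiens), read by NanoBRET (on this read-out lower numbers stand for stronger inhibition and higher numbers for weaker inhibition), compound 1 gives only a limit, > 10000 nM. In this assay compound 2 gives 2310 nM. Among the measured compounds shown here, compound 2 thus holds the only numerical value in the set; the other entry is a limit, as noted for (the limit of > 10000 nM in this assay, at which 1 of the 2 values shown sits). For the measured compounds named here, the one measured step, an at least 4.3-fold lower number from compound 1 to compound 2 (0.63 log units; beyond the scatter), concerns the group on the saturated chain carbon bound to the ring nitrogen and is bounded by that limit.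

Compound 3 `O=C(NCCCNc1nc(Nc2cccc(NC(=O)N3CCCC3)c2)ncc1C1CC1)C1CCC1` differs from compound 2 by cyclopropyl in place of hydrogen on an aromatic carbon. Going by the values given here, no measured step touches an aromatic carbon of the shared core, so the step from compound 2 to compound 3 has no direct precedent here, and no change beyond the usual scatter can be predicted in either direction with confidence. Compound 3 is therefore expected to sit near compound 2, at an estimated 1200 nM (range 250 nM to 6000 nM), which corresponds to an expected 1.9-fold lower number from compound 2 to compound 3 (0.28 log units; within the scatter).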

Compound 3, half-maximal inhibitory concentration in the serine/threonine-protein kinase 17A assay: 58.2 nM
Beside the measured number, compound 3's estimate is 21-fold (1.31 log units) above it; measured number outside the range, below it.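

In the serine/threonine-protein kinase 17A assay compound 2 gives 2310 nM and compound 3 gives 58.2 nM. Among the compounds shown here, in the serine/threonine-protein kinase 17A assay, cyclopropyl in place of hydrogen on this aromatic carbon, ortho to a large group and para to a large group, gives a 40-fold lower number from compound 2 to compound 3 (1.60 log units; beyond the scatter), the first evidence that this position of the shared core responds strongly to substitution. In a physicochemical assay for solubility, in phosphate buffer, measured as kinetic solubility, with a stated time of 24 h, at pH 7.4 (a lower number here means a less soluble compound, a higher number a more soluble compound), compound 2 gives 136000 nM and compound 3 gives 164000 nM. In the physicochemical assay, the same change gives a 1.2-fold higher number from compound 2 to compound 3 (0.08 log units; within the scatter), so this read-out shows no step beyond the scatter alongside the large step in the serine/threonine-protein kinase 17A assay. Nothing measured here bears on why the step is so large.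

As far as these compounds go, whether the step depends on cyclopropyl itself stays open, as methyl, a chlorine atom or cyclobutyl on the same carbon would show. Also open, from the compounds shown here alone, is whether it carries over to compounds with the 4-sulfamoylphenyl group of compound 1 in place of the 2-((cyclobutylcarbonyl)amino)ethyl group.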